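From 3-bromophenyl to 4-methoxyphenyl in a growth assay

The compounds below may be only part of what the source reports. "The series", "measured", "known", "first", "only" and "open" are said of these compounds alone.

In a functional assay on OCI-Ly3 cells (Homo sapiens) for inhibition, read by CellTiter-Glo, with stated times of 48 h and 96 h (on this read-out higher numbers stand for weaker inhibition of growth and lower numbers for stronger inhibition of growth), compound 1 `CCC(=O)[C@H](CCCNC(=N)N)NC(=O)[C@@H]1CCCN1C(=O)[C@@H](NC(=O)[C@H](CC(C)C)NC(=O)OCc1ccccc1)C(C)C` gives > 20000 nM as a limit of the assay. Compound 2 `CC(C)[C@H](NC(=O)c1cccc(Br)c1)C(=O)N1CCC[C@H]1C(=O)N[C@@H](CCCNC(=N)N)C(=O)CF` stands lowest at 530 nM against compound 3 `CC(C)[C@H](NC(=O)c1ccc(C#N)cc1)C(=O)N1CCC[C@H]1C(=O)N[C@@H](CCCNC(=N)N)C(=O)CF` at 6660 nM on the numbers shown. Compound 4 `COc1ccc(C(=O)N[C@H](C(=O)N2CCC[C@H]2C(=O)N[C@@H](CCCNC(=N)N)C(=O)CF)C(C)C)cc1` has yet to be measured and differs from compound 2 by 4-methoxyphenyl in place of 3-bromophenyl on a carbonyl carbon in the form of 4-methoxyphenyl in place of 3-bromophenyl on a carbonyl carbon. For the measured compounds named here, the one measured step that also replaces 3-bromophenyl on a carbonyl carbon is a 13-fold higher number from compound 2 to compound 3 (1.10 log units; beyond the scatter) and it is large and beyond the scatter. A higher number, from a step of somewhat smaller size, is therefore expected in this assay for this change. The expected step is a 3.8-fold higher number from compound 2 to compound 4 (0.58 log units; beyond the scatter) in size. Compound 4 is estimated at 2000 nM with an expected range from 500 nM to 8000 nM in this read-out.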

Compound 4, concentration for 50% growth inhibition: 1670 nM
Beside the measured number, compound 4's estimate is 1.2-fold (0.08 log units) above it; low and high end bracket the measured number.
By their numbers in this assay, from the lowest: compound 2; then compound 4; then compound 3. At a limit, above all of these: compound 1.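

In this assay, 4-methoxyphenyl in place of 3-bromophenyl on the carbonyl carbon gives a 3.2-fold higher number from compound 2 to compound 4 (0.50 log units; beyond the scatter) and so shows a second replacement of 3-bromophenyl moving the number upward. Methoxy in place of cyano on the aromatic carbon gives a 4.0-fold lower number from compound 3 to compound 4 (0.60 log units; beyond the scatter) and shows that the size of the rise depends on which group the ring carries, not only on the loss of 3-bromophenyl. On these data alone, whether a phenyl ring carrying an amine or a carboxylic acid would give a number lower than that of 3-bromophenyl remains open. Nothing shown here accounts for either step.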